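The source may hold more compounds than are shown below. What is called first, only, known or untested is meant among the compounds shown, and "the series" means these compounds.

Measured so far in an assay on COS-7 cells for inhibition of patatin-like phospholipase domain-containing protein 2 (Mus musculus); on this read-out lower numbers stand for stronger inhibition and higher numbers for weaker inhibition:
compound 1, `CCOC(=O)c1cccc(-c2ccc3c(ccn3C)c2)c1`, 75000 nM
compound 2, `CCOc1ccc(-c2cccc(NC(=O)N(C)C)c2)cc1`, 70000 nM
compound 3, `CN(C)C(=O)Nc1cccc(-c2ccc(N(C)C)cc2)c1`, < 5000 nM

Going by the values given here, for compound 3 the entry < 5000 nM is a limit of the assay and not a number; it is the one value that sits at the limit of < 5000 nM in this assay, at which 1 of the 3 values shown sits. Among the compounds with values here, the single one-place step in this assay, an at least 14-fold lower number from compound 2 to compound 3 (1.14 log units; beyond the scatter), concerns the aromatic carbon and is large.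

Compound 4, `CN(C)c1ccc(-c2cccc(NC(=O)OCc3ccccc3)c2)cc1`, differs from compound 3 by benzyloxy in place of dimethylamino on a carbonyl carbon. Within the data shown here, no measured step touches the carbonyl carbon, so none bears on this change, and the step to compound 4 cannot be sized from the data. Compound 4 is therefore expected near compound 3, with an estimate of 2500 nM in this assay, range 500 nM to 10000 nM, which would mean a step that the limit leaves unreadable from compound 3 to compound 4.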

Compound 4, half-maximal inhibitory concentration: > 200000 nM
Compound 4 was reported as a limit (the forecaster's own chance of this, stated with the estimate: 35%); middle value at least 80-fold (1.90 log units) from the limit.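

On the carbonyl carbon, the group matters strongly in this assay: benzyloxy in place of dimethylamino gives (an at least 40-fold higher number from compound 3 to compound 4 (1.60 log units; beyond the scatter)). Compound 3 is recorded only as a limit: the limit of < 5000 nM in this assay, at which 1 of the 4 values shown sits. Compound 4 is likewise recorded only as a limit: the limit of > 200000 nM in this assay, at which 1 of the 4 values shown sits.

From the compounds shown here alone, the full size of this step stays open, since neither end is a number. Also open, going by these compounds, is whether the benzyl part or the oxygen carries the change: methoxy or benzylamino on the carbonyl carbon would separate the two.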